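This account rests on a few compounds, and the source may have more. Where it says the series, first, only, none or still open, it means among the compounds named here.

Working notes on the series, read in an ADME assay on microsomes from liver (Homo sapiens) for metabolic stability, read by LC-MS, with a stated time of 10 min, tested at 0.5 uM; a higher number here means that more of the compound is left, a lower number that less of the compound is left. Going by the values given here, compound 1 `CC(C)N1CCN(CCCN(C[C@H]2Cc3ccccc3CN2)[C@H]2CCCc3cccnc32)CC1` gives 46%, and compound 2 `CN1CCN(CCCN(C[C@H]2Cc3ccccc3CN2)[C@H]2CCCc3cccnc32)CC1` gives 72%, the higher of the two numbers so far. Compound 3 `c1ccc2c(c1)CN[C@@H](CN(CCCCN1CCNCC1)[C@H]1CCCc3cccnc31)C2` has the same atoms as compound 2, joined differently: (piperazin-1-yl)methyl in place of 4-methylpiperazin-1-yl on a saturated chain carbon, three bonds along the chain from an amine nitrogen. The change is (piperazin-1-yl)methyl in place of 4-methylpiperazin-1-yl on a saturated chain carbon, three bonds along the chain from an amine nitrogen. Cut further out, it reads 3-(4-methylpiperazin-1-yl)propyl to 4-(piperazin-1-yl)butyl.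

Among the compounds with values here, only one measured step bears on this, and only in part: a number 26 percentage points higher from compound 1 to compound 2 (beyond the scatter), with methyl in place of isopropyl on an amine nitrogen in a ring. That step suggests a possible small gain from losing the methyl, but it rests on a single pair. Within the data shown here, no measured pair varies the chain length, so that half of the change is untested and could pull the other way. Little net change is expected, an estimated a number 2 percentage points higher from compound 2 to compound 3 (within the scatter). For compound 3 the expected value is 74%, with an estimated range of 54% to 92%.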

Compound 3, percent of the compound remaining: 82%
Beside the measured number, compound 3's estimate is 8 percentage points below it; the range from low to high includes it.
By their numbers in this assay, from the lowest: compound 1; then compounds 2 and 3 (each within the scatter of the next).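

The change from 3-(4-methylpiperazin-1-yl)propyl to 4-(piperazin-1-yl)butyl reads in this assay as a number 10 percentage points higher from compound 2 to compound 3 (within the scatter), so at this place on the chain the same atoms can be joined differently, with one hydrogen-bond donor entering, without a difference that exceeds the scatter. Set against 4-isopropylpiperazin-1-yl, the same entering group gives a number 36 percentage points higher from compound 1 to compound 3 (beyond the scatter), which leaves compound 1 apart from both compound 2 and compound 3 and makes the isopropyl-bearing side chain the only one of the three that stands clear of the others. Nothing at hand accounts for these numbers.

Compound 3 differs from compound 2 in both the chain and the substituent on the ring nitrogen, so the two halves of the change stay tangled, and only 3-(piperazin-1-yl)propyl and 4-(4-methylpiperazin-1-yl)butyl on the shared core could pull them apart. Also open, from the compounds shown here alone, is whether a morpholine in place of the piperazine, or a longer chain such as 5-(piperazin-1-yl)pentyl, would stay in the same band as compound 2 and compound 3.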